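Methoxy-rich stilbene-type and thioether analogues in RAW264.7 inhibition

The compounds below may be only part of what the source reports. "The series", "measured", "known", "first", "only" and "open" are said of these compounds alone.

Measured compounds:
compound 1 `COc1ccc([C@@H]2c3c(OC)cc(OC)cc3/C(=C/c3ccc(C)cc3)[C@H]2c2cc(OC)cc(OC)c2)cc1`, > 200000 nM
compound 2 `COc1ccc([C@@H]2c3c(OC)cc(OC)cc3/C(=C/c3ccc(F)cc3)[C@H]2c2cc(OC)cc(OC)c2)cc1`, > 200000 nM
compound 3 `COc1ccc([C@@H]2c3c(OC)cc(OC)cc3C(SCc3ccc(C)cc3)[C@H]2c2cc(OC)cc(OC)c2)cc1`, > 200000 nM

In a functional assay on RAW264.7 cells (Mus musculus) for inhibition, with stated times of 2 h and 24 h (on this read-out lower numbers stand for stronger inhibition and higher numbers for weaker inhibition), compound 1 gives only a limit, > 200000 nM. In this assay compound 2 likewise gives only a limit, > 200000 nM. Compound 3 also returns only a limit in this assay, > 200000 nM. The change from compound 1 to compound 2 is fluoro in place of methyl on an aromatic carbon, and the step it made, a step that the two limits leave unreadable from compound 1 to compound 2, cannot be sized because of the limit of > 200000 nM in this assay, at which 3 of the 3 values shown sit. How the core of compound 3 differs from that of compound 1 is not broken down here. Compound 4 `COc1ccc([C@@H]2c3c(OC)cc(OC)cc3C(SCc3ccc(F)cc3)[C@H]2c2cc(OC)cc(OC)c2)cc1` is not yet measured; it differs from compound 3 by fluoro in place of methyl on an aromatic carbon, the same change as from compound 1 to compound 2. Compound 4 is expected to remain at the limit, a step that the limit leaves unreadable from compound 3 to compound 4, because of the limit of > 200000 nM in this assay, at which 3 of the 3 values shown sit. The estimate for compound 4 is 300000 nM, between 100000 nM and 1000000 nM.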

Compound 4, half-maximal inhibitory concentration: > 200000 nM
Compound 4: a limit, no number (the forecaster's own chance of this, stated with the estimate: 90%); the middle value is on the limit's open side.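

No step can be read between compound 3 and compound 4, since each gives only a limit in this assay: the limit of > 200000 nM in this assay, at which 4 of the 4 values shown sit.

The compounds shown leave open whether fluoro in place of methyl on an aromatic carbon changes inhibition at all, and how strongly any of the four compounds inhibits.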